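This account rests on a few compounds, and the source may have more. Where it says the series, first, only, none or still open, it means among the compounds named here.

Measured in a functional assay on PANC-1 cells (Homo sapiens) for inhibition, read by MTT assay, with a stated time of 72 h; a lower number here means a stronger inhibitor of growth, a higher number a weaker inhibitor of growth:
Compound 1, `O=S(=O)(NCCCNCc1cccc2ccccc12)c1cc(C(F)(F)F)cc(C(F)(F)F)c1`, gives 2700 nM.
Compound 2, `COc1cccc(CNCCCNS(=O)(=O)c2cc(C(F)(F)F)cc(C(F)(F)F)c2)c1`, gives 10000 nM.
Compound 3, `O=S(=O)(NCCCNCc1ccccc1Cl)c1cc(C(F)(F)F)cc(C(F)(F)F)c1`, gives 15000 nM.

Compound 3 sits at the weak end of this small set: the step of a 5.6-fold higher number from compound 1 to compound 3 (0.74 log units; beyond the scatter) lies beyond the scatter, whereas a 1.5-fold higher number from compound 2 to compound 3 (0.18 log units; within the scatter) lies within it, so compound 3 and compound 2 cannot be told apart. Compound 4, `O=S(=O)(NCCCNCc1ccc(Br)cc1)c1cc(C(F)(F)F)cc(C(F)(F)F)c1`, differs from compound 3 in one place: 4-bromophenyl in place of 2-chlorophenyl on a saturated chain carbon bound to an amine nitrogen. Among the compounds with values here, no measured step swaps one substituted phenyl for another while keeping the same chain, and the only step between two such phenyl groups, a 1.5-fold higher number from compound 2 to compound 3 (0.18 log units; within the scatter), was within the scatter; the larger steps of a 3.7-fold higher number from compound 1 to compound 2 (0.57 log units; beyond the scatter) and a 5.6-fold higher number from compound 1 to compound 3 (0.74 log units; beyond the scatter) both involve leaving the naphthalenyl group. On that basis compound 4 is expected to give roughly 12000 nM, somewhere between 5000 nM and 30000 nM, an expected step of a 1.3-fold lower number from compound 3 to compound 4 (0.10 log units; within the scatter).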

Compound 4, concentration for 50% growth inhibition: 2200 nM
For compound 4 the middle estimate is 5.5-fold (0.74 log units) above the measured one; the whole stated range lies above it.
By their numbers in this assay, from the lowest: compounds 4 and 1 (each within the scatter of the next); then compounds 2 and 3 (each within the scatter of the next).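

This position does respond to a swap between substituted phenyl groups: 4-bromophenyl in place of 2-chlorophenyl gives a 6.8-fold lower number from compound 3 to compound 4 (0.83 log units; beyond the scatter), and in place of 3-methoxyphenyl it gives a 4.5-fold lower number from compound 2 to compound 4 (0.66 log units; beyond the scatter). Losing the naphthalen-1-yl group therefore need not cost growth inhibition, as the step (a 1.2-fold lower number from compound 1 to compound 4 (0.09 log units; within the scatter)) shows no difference that can be told from scatter. No evidence available here explains these differences.

Compound 3 and compound 4 differ in both the halogen and its place on the ring, so the two remain unseparated. A 4-chlorophenyl or 2-bromophenyl group would be needed to pull them apart.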